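The source may hold more compounds than are shown below. What is called first, only, known or untested is meant among the compounds shown, and "the series" means these compounds.

Two compounds carrying the same core have been examined in a functional assay on MCF7 cells (Homo sapiens) for inhibition, read by sulforhodamine B assay, with a stated time of 48 h; on this read-out lower numbers stand for higher toxicity in this test and higher numbers for lower toxicity in this test. Compound 1, `CCOC(=O)[C@H](CCC(=O)O)NC(=O)c1ccc(CNc2nc3cc(N)cc(N)c3nc2-c2ccccc2)cc1`, carries a longer side chain ending in an ester and an acid. In this assay compound 1 gives < 100000 nM, which is a limit of the assay and not a number. Compound 2, `Nc1cc(N)c2nc(-c3ccccc3)c(NCc3ccc(Cl)c(Cl)c3)nc2c1`, carries a shorter side chain. In this assay compound 2 gives < 100000 nM, again a limit of the assay and not a number. Compound 2 therefore stands at the same place as the other value shown, since (the limit of < 100000 nM in this assay, at which 2 of the 2 values shown sit); nothing separates the two compounds on the numbers available.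

Compound 3, `COc1ccc(CNc2nc3cc(N)cc(N)c3nc2-c2ccccc2)cc1OC`, is not yet measured. It differs from compound 2 in one place: 3,4-dimethoxyphenyl in place of 3,4-dichlorophenyl on a saturated chain carbon bound to a nitrogen on an aromatic ring. For the measured compounds named here, no measured step between two compounds is available to guide the size of this change. With both measured values sitting at the limit, the step from compound 2 to compound 3 is expected to be a step that the limit leaves unreadable from compound 2 to compound 3, and most likely within the scatter. For compound 3 the expected value in this assay is 50000 nM, between 10000 nM and 100000 nM, with a high chance that only a limit is reported again.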

Compound 3, concentration lethal to 50% of the cells: < 100000 nM
Compound 3 was reported as a limit; the forecaster's own chance of this, stated with the estimate: 70%; the middle value does not contradict the limit.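

Going from compound 2 to compound 3, with 3,4-dimethoxyphenyl in place of 3,4-dichlorophenyl, gives a step whose size cannot be read, because both results are limits of the assay and not numbers: the limit of < 100000 nM in this assay, at which 3 of the 3 values shown sit. The compounds shown leave open where each one's true value lies in this assay, and whether changing the side chain alters it at all.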